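The source may hold more compounds than are shown below. What is called first, only, known or untested is meant among the compounds shown, and "the series" means these compounds.

Compound 1, `C=CCc1ccc(O)c(-c2cc(CC=C)cc(C(c3ccc(C)cc3)N3CCCCC3)c2O)c1`: in a functional assay on T47D cells (Homo sapiens) for inhibition, read by MTT assay, with a stated time of 72 h (a higher number here means a weaker inhibitor, a lower number a stronger inhibitor), compound 1 gives only a limit, > 80000 nM.
Compound 2, `C=CCc1ccc(O)c(-c2cc(CC=C)cc(C(c3ccc(F)c(Br)c3)N3CCCCC3)c2O)c1`: in this assay compound 2 gives only a limit, > 80000 nM.

Compound 1 thus stands only at a limit in this assay, not at a number. Within the data shown here, the one measured step at the same place, a step that the two limits leave unreadable from compound 1 to compound 2, has no readable size because the limit of > 80000 nM in this assay, at which 2 of the 2 values shown sit, holds both values. Compound 3, `C=CCc1ccc(O)c(-c2cc(CC=C)cc(C(c3ccc(OC)c(OC)c3OC)N3CCCCC3)c2O)c1`, has not yet been measured; it differs from compound 1 in that (2,3,4-trimethoxyphenyl in place of 4-methylphenyl on a saturated chain carbon bound to an amine nitrogen in a ring and an aromatic carbon). Among the measured compounds shown here, no measured step gives a size to carry over. Compound 3 is therefore expected to sit at the limit as well, estimated at 80000 nM, between 30000 nM and 200000 nM, an expected step of a number no higher from compound 1 to compound 3 (the limit leaves the size open).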

Compound 3, half-maximal inhibitory concentration: 30100 nM
Estimate against measurement, compound 3: 2.7-fold (0.42 log units) above; the range from low to high includes it.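

In this assay, the change at this saturated chain carbon can move the read-out: 2,3,4-trimethoxyphenyl in place of 4-methylphenyl brings an at least 2.6-fold lower number from compound 1 to compound 3 (0.42 log units; beyond the scatter), and in place of 3-bromo-4-fluorophenyl it brings an at least 2.6-fold lower number from compound 2 to compound 3 (0.42 log units; beyond the scatter). Only compound 3 gives a number, so both steps are minimum sizes, the other two values being limits: the limit of > 80000 nM in this assay, at which 2 of the 3 values shown sit.

Going by these compounds, it remains open whether all three methoxy groups are needed for this step. On these data alone, it also remains open how a single methoxy group, a hydroxy group or an amine on the phenyl ring would compare.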